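The source may report more compounds than this note shows. Statements on the series, on what has been measured and on what is new or still open speak of the compounds shown alone.

Three compounds share one core and differ only in the group on the amide nitrogen. Compound 1 `Cc1noc(C)c1-c1cnc(N)c(Oc2ccc(C(=O)NC3CC3)cc2)n1` carries a cyclopropyl there, and in a functional assay on HeLa cells (Homo sapiens) for inhibition, read by MTT assay, with a stated time of 72 h (a higher number here means a weaker inhibitor, a lower number a stronger inhibitor), compound 1 gives 17800 nM. Compound 2 `Cc1noc(C)c1-c1cnc(N)c(Oc2ccc(C(=O)Nc3ccc(Cl)cn3)cc2)n1` carries a 5-chloropyridin-2-yl, and in this assay compound 2 gives 19200 nM. Compound 3 `Cc1noc(C)c1-c1cnc(N)c(Oc2ccc(C(=O)Nc3cc(Cl)ccn3)cc2)n1` carries a 4-chloropyridin-2-yl, and in this assay compound 3 gives 37900 nM. Among these three numbers compound 2 has the second highest: there is a 1.1-fold higher number from compound 1 to compound 2 (0.03 log units; within the scatter) and a 2.0-fold higher number from compound 2 to compound 3 (0.30 log units; within the scatter), while the widest measured spread is a 2.1-fold higher number from compound 1 to compound 3 (0.33 log units; beyond the scatter).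

Compound 4 `Cn1cc(-c2cnc(N)c(Oc3ccc(C(=O)Nc4ccc(Cl)cn4)cc3)n2)cn1` keeps the amide group of compound 2 and instead changes the five-membered ring attached to the core: 1-methyl-1H-pyrazol-4-yl in place of 3,5-dimethyl-1,2-oxazol-4-yl on an aromatic carbon. For the measured compounds named here, none of the measured steps touches this ring; all three swap the group on the amide nitrogen, and the largest of them was only a 2.1-fold higher number from compound 1 to compound 3 (0.33 log units; beyond the scatter). Going by the values given here, there is thus no measured step that bears directly on the change from compound 2 to compound 4, and the expectation rests on the narrow spread of the three numbers seen so far. For compound 4 the expected step is a 1.0-fold higher number from compound 2 to compound 4 (0.02 log units; within the scatter), with no clear direction. In this assay compound 4 is estimated at 20000 nM, with a range from 6000 nM to 60000 nM.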

Compound 4, half-maximal inhibitory concentration: 21500 nM
Beside the measured number, compound 4's estimate is 1.1-fold (0.03 log units) below it; the range from low to high includes it.
By their numbers in this assay, from the lowest: compounds 1, 2, 4 and 3 (each within the scatter of the next, the first and the last beyond it).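

Until now every step changed the group on the amide nitrogen, so the five-membered ring on the other side of the shared core had not been tested. In this assay, placing 1-methyl-1H-pyrazol-4-yl where 3,5-dimethyl-1,2-oxazol-4-yl stood gives a 1.1-fold higher number from compound 2 to compound 4 (0.05 log units; within the scatter), which shows that this exchange at the ring position leaves the number unchanged within the scatter, even though the two groups differ in their heavy atoms and in the arrangement of their hetero atoms. The data on hand offer no measurement that could explain this lack of change.

Going by these compounds, this is a close swap, since both groups are five-membered aromatic rings with the same hydrogen-bond donor and acceptor counts, so it remains open whether a larger or very different group at this position, such as a phenyl ring, a morpholine or a carboxylic acid, would move the number. The step is also read only with the 5-chloropyridin-2-yl amide, which leaves open whether the same exchange would give so small a step with the cyclopropyl amide of compound 1 or the 4-chloropyridin-2-yl amide of compound 3.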